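Compound 3: a new group on the aromatic nitrogen

The source may hold more compounds than are shown below. What is called first, only, known or untested is meant among the compounds shown, and "the series" means these compounds.

In a functional assay on PC-3 cells (Homo sapiens) for cytotoxicity, read by cell counting, with a stated time of 48 h (a lower number here means a stronger inhibitor, a higher number a weaker inhibitor), compound 1 (`Clc1cccc(Nc2ncc3cccc(OCc4cn(Cc5c(Cl)cccc5Cl)nn4)c3n2)c1`) gives 7000 nM and compound 2 (`COc1cccc(-n2cc(COc3cccc4cnc(Nc5cccc(Cl)c5)nc34)nn2)c1`) gives 10000 nM. Among the measured compounds shown here, these two numbers lie within the scatter of each other, so compound 2 stands level with the only other measured compound.

Compound 3 (`Clc1cccc(Nc2ncc3cccc(OCc4cn(-c5cc(Cl)cc(Cl)c5)nn4)c3n2)c1`) has 3,5-dichlorophenyl in place of 3-methoxyphenyl on an aromatic nitrogen of a five-membered aromatic ring with 3 nitrogen: 3,5-dichlorophenyl in place of 3-methoxyphenyl on an aromatic nitrogen.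

For the measured compounds named here, one measured step bears on this change, as it falls on the same nitrogen: a 1.4-fold higher number from compound 1 to compound 2 (0.15 log units; within the scatter). There, 3-methoxyphenyl took the place of 2,6-dichlorobenzyl, and the number stayed within the scatter. Going by the values given here, this is a single step, and no measured compound carries 3,5-dichlorophenyl, so the evidence is thin and the range must stay wide.

No step beyond the scatter is therefore expected in this assay, in either direction. The estimated step is a 1.3-fold lower number from compound 2 to compound 3 (0.10 log units; within the scatter). For compound 3 the expected value is 8000 nM, with an estimated range of 3000 nM to 20000 nM.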

Compound 3, half-maximal inhibitory concentration: 8000 nM
Compound 3: middle estimate and measured number agree at the digits printed, within the range that was stated.
By their numbers in this assay, from the lowest: compounds 1, 3 and 2 (each within the scatter of the next).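

In this assay the change from 3-methoxyphenyl to 3,5-dichlorophenyl on the aromatic nitrogen gives a 1.3-fold lower number from compound 2 to compound 3 (0.10 log units; within the scatter) and stays within the scatter, while the change from 2,6-dichlorobenzyl to 3,5-dichlorophenyl at the same place gives a 1.1-fold higher number from compound 1 to compound 3 (0.06 log units; within the scatter) and also stays within the scatter. All three groups at this position now stand level, and the exchange of the single hydrogen-bond acceptor of 3-methoxyphenyl for the two chlorine atoms of 3,5-dichlorophenyl, at an equal count of heavy atoms, does not move the number beyond the scatter. No measurement at hand accounts for this flat result.

The three groups shown are all chlorine- or methoxy-bearing aromatic rings, so it remains open whether an amine, a carboxylic acid or a longer chain on the same nitrogen would give a step beyond the scatter. On these data alone, it is also open whether any change elsewhere on the shared core would shift the number further than changes at this nitrogen have done.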